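Series notes: two aryl substitutions on a shared core

This account rests on a few compounds, and the source may have more. Where it says the series, first, only, none or still open, it means among the compounds named here.

Measured so far:
- Compound 1 `COc1cc2cc(Oc3ccc(NC(=O)Nc4cccc(C(F)(F)F)c4)cc3)c(C)nc2cc1OC`: 4900 nM
- Compound 2 `COc1cc2cc(Oc3ccc(NC(=O)Nc4ccc(Cl)c(C(F)(F)F)c4)cc3)c(C)nc2cc1OC`: 5710 nM

Both compounds were run in a functional assay on Malme-3M cells (Homo sapiens) for inhibition, read by sulforhodamine B assay, with a stated time of 48 h; on this read-out lower numbers stand for stronger inhibition of growth and higher numbers for weaker inhibition of growth. Compound 1 gives 4900 nM and compound 2 gives 5710 nM. Among the compounds with values here, the one measured step is a 1.2-fold higher number from compound 1 to compound 2 (0.07 log units; within the scatter), so the two numbers cannot be told apart. Of the two, compound 2 has the higher number, with compound 1 the nearest neighbour.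

Compound 3 `COc1cc2cc(Oc3ccc(NC(=O)Nc4ccc(Cl)c(Cl)c4)cc3)c(C)nc2cc1OC` has not yet been measured in this assay. Relative to compound 2 the change is chloro in place of trifluoromethyl on an aromatic carbon. Within the data shown here, no measured step replaces a trifluoromethyl group with a chloro group, so nothing bears directly on this change; the single step from compound 1 to compound 2, which touched the same ring and stayed within the scatter, is the only guide and suggests that substitution on this ring has so far moved the numbers little.

On that basis no step beyond the scatter is expected, and the estimated step in this assay is a 1.0-fold lower number from compound 2 to compound 3 (0.02 log units; within the scatter). Compound 3 is expected to give about 5500 nM, with a range from 2500 nM to 12000 nM.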

Compound 3, concentration for total growth inhibition: 7720 nM
Compound 3: middle estimate off by 1.4-fold (0.15 log units), on the low side, within the range that was stated.
By their numbers in this assay, from the lowest: compounds 1, 2 and 3 (each within the scatter of the next).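

In this assay the place ortho to a chloro group now has a direct reading: chloro in place of trifluoromethyl gives a 1.4-fold higher number from compound 2 to compound 3 (0.13 log units; within the scatter) and leaves the number within the scatter, a change the earlier pair did not cover. The wider comparison, 3,4-dichlorophenyl in place of 3-(trifluoromethyl)phenyl on an amide-type nitrogen, gives a 1.6-fold higher number from compound 1 to compound 3 (0.20 log units; within the scatter) and also stays within the scatter, so the three aryl patterns shown cannot be separated in this read-out, and none of the three can be called stronger or weaker than the others. No measurement is available that would explain how closely these numbers sit.

The compounds shown leave open whether a group of a different kind at this place, such as an amine, a carboxylic acid or a longer alkyl chain, would move the number beyond the scatter. Also open, on these data alone, is whether the same exchange of trifluoromethyl for chloro stays this small without the neighbouring chloro group, since both compounds of the direct step carry it.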